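Cytotoxicity of three measured analogues and one new variant

The compounds below may be only part of what the source reports. "The series", "measured", "known", "first", "only" and "open" are said of these compounds alone.

Compound 3 `COc1ccccc1-c1cn(C/C=C2\OC(=O)C(OCc3ccccc3)=C2OCc2ccccc2)nn1` was examined in an ADME assay on HFF cells (Homo sapiens) for cytotoxicity, read by MTT assay, with a stated time of 72 h; a lower number here means a stronger inhibitor, a higher number a weaker inhibitor. There compound 3 gives only a limit of the assay, > 100000 nM. Compound 1 `O=C1O/C(=C\Cn2cc(-c3cc(F)cc(F)c3)nn2)C(OCc2ccccc2)=C1OCc1ccccc1` likewise returns only a limit, > 100000 nM. Compound 2 `CCCCCc1ccc(-c2cn(C/C=C3\OC(=O)C(OCc4ccccc4)=C3OCc3ccccc3)nn2)cc1` also shows only a limit, > 100000 nM. The steps a step that the two limits leave unreadable from compound 1 to compound 2, a step that the two limits leave unreadable from compound 1 to compound 3 and a step that the two limits leave unreadable from compound 2 to compound 3 therefore cannot be sized, since every value sits at the limit of > 100000 nM in this assay, at which 3 of the 3 values shown sit. Compound 3 thus stands at the limit, indistinguishable from the other two on the numbers available. Compound 4 `O=C1O/C(=C\Cn2cc(-c3cccc(O)c3)nn2)C(OCc2ccccc2)=C1OCc1ccccc1` differs from compound 3 by 3-hydroxyphenyl in place of 2-methoxyphenyl on an aromatic carbon. For the measured compounds named here, no measured step bears on this change, as all three measured values rest at the limit. The step expected from this is a number no higher from compound 3 to compound 4 (the limit leaves the size open), none beyond the scatter. Compound 4 is accordingly estimated at 100000 nM, most probably again reported only as a limit, with a range of 30000 nM to 300000 nM.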

Compound 4, half-maximal inhibitory concentration: 42600 nM
Compound 4: the middle estimate sits 2.3-fold (0.37 log units) above what was measured; the range from low to high includes it.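

Changing the group on this aromatic carbon can bring a readable number in this assay: 3-hydroxyphenyl gives an at least 2.3-fold lower number from compound 3 to compound 4 (0.37 log units; beyond the scatter), an at least 2.3-fold lower number from compound 2 to compound 4 (0.37 log units; beyond the scatter) and an at least 2.3-fold lower number from compound 1 to compound 4 (0.37 log units; beyond the scatter). Each step is only a minimum, as each starts from a limit of the assay. Compound 4 alone gives a number, and its 3-hydroxyphenyl alone among these groups carries a hydrogen-bond donor: the limit of > 100000 nM in this assay, at which 3 of the 4 values shown sit.

With a single such compound, the shift cannot be tied to that donor. As far as these compounds go, it remains open whether an amine or a carboxylic acid in place of the hydroxyl would also give a number rather than a limit.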